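A few compounds are considered here, and "the series" means these few. Any claim that something is new, unique, unknown or untested is made for them only; others in the source may bear on it.

In an ADME assay on Vero cells (Chlorocebus sabaeus) for cytotoxicity, read by MTT assay, with a stated time of 72 h (on this read-out lower numbers stand for an effect already at smaller amounts and higher numbers for an effect only at larger amounts of compound), compound 1 `CC(=O)c1ccccc1C(=O)Nc1nc(-c2ccccn2)cs1` gives 86700 nM and compound 2 `O=C(Nc1nc(-c2ccccn2)cs1)c1ccccc1Cl` gives 2000 nM. For compound 3 `O=C(Nc1nc(-c2ccccn2)cs1)c1ccccc1F` the entry reads "not determined" (no result reported), so it has no place on this scale and offers no starting number. Compound 4 `O=C(Nc1nc(-c2ccccn2)cs1)c1c(F)cccc1Cl` differs from compound 3 in one place: chloro in place of hydrogen on an aromatic carbon.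

For the measured compounds named here, only one measured step bears on this change: a 43-fold lower number from compound 1 to compound 2 (1.64 log units; beyond the scatter). That step is large and beyond the scatter, and it also brings in chloro on an aromatic carbon. There, however, chloro replaces acetyl rather than hydrogen, so it is only a loose guide. A step towards a lower number is expected in this assay, probably a smaller one than the step to compound 2, although its size cannot be checked without a value for compound 3. The nearest anchor is compound 2 at 2000 nM, which also carries chloro.

For compound 4 the estimated value is 2500 nM, with an expected range from 700 nM to 10000 nM.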

Compound 4, half-maximal effective concentration: 1300 nM
Compound 4: middle estimate off by 1.9-fold (0.28 log units), on the high side, and the stated range covers the measured number.
By their numbers in this assay, from the lowest: compounds 4 and 2 (each within the scatter of the next); then compound 1.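

In this assay the new step is a 1.5-fold lower number from compound 2 to compound 4 (0.19 log units; within the scatter) and so, with chloro already on the ring, adding fluoro makes no difference that can be told from the scatter. The step from compound 3 to compound 4 cannot be read, which leaves the effect of chloro in place of hydrogen on this ring without a direct measure. Nothing measured here accounts for these numbers.

Still open, on these data alone, is whether another group on this ring, such as methoxy or an amine, would stay close to compound 2 and compound 4 or would lie nearer to compound 1 (86700 nM), which carries acetyl. Also open, as far as these compounds go, is how the ring would behave with hydrogen in place of both chloro and fluoro.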